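The source may report more compounds than this note shows. Statements on the series, on what has been measured and on what is new or still open speak of the compounds shown alone.

In a functional assay on K562 cells (Homo sapiens) for cytotoxicity, read by trypan blue exclusion, with a stated time of 96 h (a lower number here means a stronger inhibitor, a higher number a weaker inhibitor), compound 1 (`COc1ccc(/C=C/S(=O)(=O)Cc2ccc(OC)c(N)c2)cc1`) gives 2500 nM and compound 2 (`COc1ccc(N)cc1CS(=O)(=O)/C=C/c1c(OC)cccc1OC`) gives 25000 nM, the higher of the two numbers and beyond the scatter. Compound 3 (`COc1cc(OC)c(/C=C/S(=O)(=O)Cc2cc(N)ccc2OC)c(OC)c1`) carries methoxy in place of hydrogen on an aromatic carbon of compound 2: methoxy in place of hydrogen on an aromatic carbon. Among the measured compounds shown here, no measured step isolates this change, so the expectation is loose. For the measured compounds named here, with compound 2 at the high end of the numbers so far, a step to a lower number, beyond the scatter, is expected in this assay. The estimated change is a 50-fold lower number from compound 2 to compound 3 (1.70 log units; beyond the scatter). For compound 3 the expected value is 500 nM, with an estimated range of 50 nM to 8000 nM.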

Compound 3, half-maximal inhibitory concentration: 7500 nM
Beside the measured number, compound 3's estimate is 15-fold (1.18 log units) below it; measured number inside the range.
By their numbers in this assay, from the lowest: compound 1; then compound 3; then compound 2.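

In this assay, among the compounds shown here, the methoxy placed meta to two methoxy groups and para to a large group gives a 3.3-fold lower number from compound 2 to compound 3 (0.52 log units; beyond the scatter), the first single-place step, and a modest one. This position therefore accepts the added methoxy, and the number moves down rather than up. No evidence on hand gives a cause for this step. Open: whether an ethoxy, a hydroxyl or a fluorine at this position would move the number further, and whether methoxy here gives a similar step on another core.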